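Pyridin-4-yl in place of 4-hydroxyphenyl: working notes

The compounds below may be only part of what the source reports. "The series", "measured", "known", "first", "only" and "open" are said of these compounds alone.

Compound 1 `O=C(NNc1ccnc2cc(Cl)ccc12)c1ccccc1/N=C/c1ccc([N+](=O)[O-])cc1`: 4.58
Compound 2 `O=C(NNc1ccnc2cc(Cl)ccc12)c1ccccc1/N=C/c1ccc(O)cc1`: 4.65
Compound 3 `O=C(NNc1ccnc2cc(Cl)ccc12)c1ccccc1/N=C/c1ccncc1`: not yet measured

In a physicochemical assay for lipophilicity, measured as octanol-water partition (a lower number here means a more polar compound, a higher number a more lipophilic compound), compound 2 stands at 4.65, level with compound 1 within the scatter. The change under review is pyridin-4-yl in place of 4-hydroxyphenyl on a carbon with a double bond to nitrogen. Among the measured compounds shown here, one measured step bears on it: a number 0.07 log units higher from compound 1 to compound 2 (within the scatter), with hydroxy in place of nitro on an aromatic carbon. For the measured compounds named here, that step exchanged a substituent, and no measured step exchanges the ring itself, so its guidance is loose. A modest downward move is expected, estimated as a number 0.55 log units lower from compound 2 to compound 3 (beyond the scatter). For compound 3 the expected value is 4.1, with a range of 3.6 to 4.6.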

Compound 3, partition coefficient: 3.86
For compound 3 the middle estimate is 0.24 log units above the measured one; the measured number falls inside the stated range.
By their numbers in this assay, from the lowest: compound 3; then compounds 1 and 2 (each within the scatter of the next).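

In this assay, exchanging the whole ring on the carbon with a double bond to nitrogen moves the number beyond the scatter (a number 0.79 log units lower from compound 2 to compound 3 (beyond the scatter)), which the substituent exchange did not do. The move runs the same way whichever substituted phenyl ring leaves (a number 0.72 log units lower from compound 1 to compound 3 (beyond the scatter)), so this position does respond to a change of ring. No measurement at hand accounts for the shift.

Open, from the compounds shown here alone, is whether an unsubstituted phenyl ring, or a phenyl ring carrying an amine or a carboxylic acid, would stay level with compound 1 and compound 2 or fall toward compound 3.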